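Biaryl imidazoline ethers: hydroxyphenyl to methylphenyl

This account rests on a few compounds, and the source may have more. Where it says the series, first, only, none or still open, it means among the compounds named here.

Two members of this series have numbers in an assay on CHO cells for displacement of a labelled ligand from Alpha-2C adrenergic receptor (Homo sapiens); on this read-out lower numbers stand for stronger inhibition and higher numbers for weaker inhibition. Compound 1 `CC(Oc1ccccc1-c1ccccc1[N+](=O)[O-])C1=NCCN1` gives 1230 nM in this assay. Compound 2 `CC(Oc1ccccc1-c1ccc(O)cc1)C1=NCCN1` gives 331 nM in this assay, the lowest of the two numbers; its nearest neighbour is compound 1, whose number is higher by a margin beyond the scatter. Compound 3 `Cc1ccccc1-c1ccccc1OC(C)C1=NCCN1` has not yet been measured in this assay. It differs from compound 2 in one place: 2-methylphenyl in place of 4-hydroxyphenyl on an aromatic carbon. The hydrogen-bond donor and acceptor of the 4-hydroxyphenyl are gone, and a substituent now sits on the entering ring ortho to a group of 8 heavy atoms. Going by the values given here, no step between measured compounds covers this change, so the size of the step is uncertain. A moderate rise in number, beyond the scatter, is expected for compound 3, a step of a 2.1-fold higher number from compound 2 to compound 3 (0.33 log units; beyond the scatter) in this assay. Compound 3 is estimated at 700 nM in this assay, within 200 nM to 2500 nM.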

Compound 3, inhibition constant: 234 nM
Estimate against measurement, compound 3: 3.0-fold (0.48 log units) above; the range from low to high includes it.
By their numbers in this assay, from the lowest: compounds 3 and 2 (each within the scatter of the next); then compound 1.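

In this assay, 2-methylphenyl in place of 4-hydroxyphenyl gives a 1.4-fold lower number from compound 2 to compound 3 (0.15 log units; within the scatter), so the hydrogen-bond donor and acceptor of the 4-hydroxyphenyl are not required to hold the number at this level. On the aromatic carbon ortho to a group of 8 heavy atoms, the choice of group does register: methyl in place of nitro gives a 5.3-fold lower number from compound 1 to compound 3 (0.72 log units; beyond the scatter), a modest step but the only one here that clears the scatter. No data are available to explain either step.

The change from compound 2 to compound 3 alters both the group and where it sits on the ring, and these two effects cannot yet be separated. Also open, from the compounds shown here alone, is how a methoxy group, a chlorine atom or an amine on that same aromatic carbon would compare with methyl and nitro.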